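The source may report more compounds than this note shows. Statements on the series, on what has been measured and on what is new or still open speak of the compounds shown alone.

The series shares the core of compound 1 `COCCOCCOCCOCc1ccc2c(Br)cc(Br)c(O)c2n1`, which in an ADME assay on HeLa cells (Homo sapiens) for cytotoxicity, read by LDH release, with a stated time of 24 h (on this read-out lower numbers stand for stronger inhibition and higher numbers for weaker inhibition), gives 100000 nM. Compound 2 `COCCOCCOCc1ccc2c(Br)cc(Br)c(O)c2n1` carries a shorter chain. In this assay compound 2 sits at a limit of the assay, > 100000 nM. Compound 3 `COCCOCc1ccc2c(Br)cc(Br)c(O)c2n1` is shorter again. In this assay compound 3 likewise sits at a limit, > 100000 nM. Two of the three values shown thus sit at the limit of > 100000 nM in this assay, at which 2 of the 3 values shown sit. The step of a number no lower from compound 1 to compound 2 (the limit leaves the size open), the step of a number no lower from compound 1 to compound 3 (the limit leaves the size open) and the step that the two limits leave unreadable from compound 2 to compound 3 read no more than the limits allow, so shortening the chain has not brought any number down. Compound 4 `CCCNCc1ccc2c(Br)cc(Br)c(O)c2n1` differs from compound 3 by propylamino in place of 2-methoxyethoxy on a saturated chain carbon bound to an aromatic carbon. Among the measured compounds shown here, none of the measured steps introduces propylamino; each only replaces part of the chain with hydrogen, so they bear on this change merely in showing that the chain end has so far left the read-out at its limit. For compound 4 in this assay a step of a number no higher from compound 3 to compound 4 (the limit leaves the size open) that stays within the scatter is expected. The estimate for compound 4 is 100000 nM, between 30000 nM and 300000 nM.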

Compound 4, half-maximal inhibitory concentration: > 100000 nM
Compound 4: a limit, no number; the forecaster's own chance of this, stated with the estimate: 60%; the middle value lies on the limit itself.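

In this assay, among the compounds shown here, compound 3 and compound 4 both stand at a limit, not a number, so no step between them can be read: the limit of > 100000 nM in this assay, at which 3 of the 4 values shown sit. The compounds shown leave open whether propylamino in place of 2-methoxyethoxy changes the read-out at all.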